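Swapping a methyl for phenyl on a shared core

The source may hold more compounds than are shown below. What is called first, only, known or untested is meant among the compounds shown, and "the series" means these compounds.

Measured so far:
Compound 1, `Cc1cc2c(c(N)nn2C)c(N2CCCCC2)n1`, gives 0% in an assay on isolated protein for inhibition of RAC-beta serine/threonine-protein kinase (Homo sapiens), read by mobility shift assay, tested at 30 uM; on this read-out higher numbers stand for more inhibition at the one concentration tested (going by the name of the read-out) and lower numbers for less inhibition.
Compound 2, `Cc1cc2nn(-c3ccccc3)c(N)c2c(=O)[nH]1`, gives 1% in this assay.

Both numbers sit at the bottom of the scale, and they lie within the usual scatter of each other, so neither compound can be said to inhibit more than the other in this assay. Compound 2 is the starting point for the next step. The new compound is compound 3, `Nc1c2c(=O)[nH]c(-c3ccccc3)cc2nn1-c1ccccc1`. The change from compound 2 to compound 3 is phenyl in place of methyl on an aromatic carbon, on the aromatic carbon of the six-membered ring that is part of the fused system, next to the ring nitrogen.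

For the measured compounds named here, no pair of measured compounds shows what such a change does here, so there is nothing to lean on beyond the two numbers themselves. Since compound 2 gives 1%, the expectation is a step of a number 3 percentage points higher from compound 2 to compound 3 (within the scatter), that is, nothing beyond the scatter. Compound 3 is estimated to give 4%, between -6% and 20%.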

Compound 3, a percentage reported as inhibition, at one concentration (the size of the read-out at that concentration, not a potency): -1%
Compound 3: middle estimate off by 5 percentage points, on the high side; the measured number falls inside the stated range.
By their numbers in this assay, from the lowest: compounds 3, 1 and 2 (each within the scatter of the next).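

Measured in this assay the exchange of methyl for phenyl on the aromatic carbon next to the ring nitrogen gives a step of a number 2 percentage points lower from compound 2 to compound 3 (within the scatter) and leaves compound 2 and compound 3 impossible to tell apart. For the compounds shown here, this is the first reading at this position, and it shows that putting a group of six heavy atoms, with a whole aromatic ring, where a single carbon stood does not bring inhibition into view at the one concentration tested. Nothing available explains this result, and with both compounds at the bottom of the scale it cannot be said whether this position matters for inhibition at all.

Going by these compounds, whether an amine, a carboxylic acid or a longer chain on this carbon would give a reading clearly above the bottom of the scale remains open. Also open, on these data alone, is how the same exchange of methyl for phenyl would read on a compound that already shows clear inhibition, since a step between two readings at the bottom of the scale has little room to show anything.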